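The compounds below may be only part of what the source reports. "The series", "measured", "known", "first", "only" and "open" are said of these compounds alone.

Measured so far in an ADME assay on microsomes (Mus musculus) for metabolic stability; a lower number here means slower removal, a higher number faster removal of the compound:

- Compound 1 `CNC(=O)[C@@H]1CCCN1S(=O)(=O)c1ccc(Cl)c(COc2cccc3c(-n4ccnc4)cc(C)nc23)c1Cl`: 267 mL/min/kg
- Compound 2 `CCc1cc(C(F)(F)F)c2cccc(OCc3c(Cl)ccc(S(=O)(=O)N4CCC[C@H]4C(=O)NC)c3Cl)c2n1`: 1280 mL/min/kg
- Compound 3 `Cc1cc(C(F)(F)F)c2cccc(OCc3c(Cl)ccc(S(=O)(=O)N4CCC[C@H]4C(=O)O)c3Cl)c2n1`: 13.3 mL/min/kg

Compound 3 at 13.3 mL/min/kg holds the lowest of these three numbers, and the gaps up to compound 1 and compound 2 both lie beyond the usual scatter. The next compound to be tested is compound 4 `Cc1cc(C(F)(F)F)c2cccc(OCc3c(Cl)ccc(S(=O)(=O)N4CCCC4)c3Cl)c2n1`. Its difference from compound 3 is hydrogen in place of carboxy on a saturated ring carbon, next to the ring nitrogen, so that 2-carboxypyrrolidin-1-yl becomes pyrrolidin-1-yl. Among the measured compounds shown here, no measured pair isolates this change. Still, the two compounds without the carboxy group, compound 1 at 267 mL/min/kg and compound 2 at 1280 mL/min/kg, both sit well above compound 3, though they also differ elsewhere. A large rise beyond the scatter in this assay is therefore expected, and the estimated step is a 23-fold higher number from compound 3 to compound 4 (1.35 log units; beyond the scatter) in size. For compound 4 the estimated clearance is 300 mL/min/kg with an expected range of 100 mL/min/kg to 900 mL/min/kg when it is measured.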

Compound 4, clearance: 967 mL/min/kg
For compound 4 the middle estimate is 3.2-fold (0.51 log units) below the measured one; measured number outside the range, above it.
By their numbers in this assay, from the lowest: compound 3; then compound 1; then compounds 4 and 2 (each within the scatter of the next).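

In this assay, the change from 2-carboxypyrrolidin-1-yl to pyrrolidin-1-yl, with the rest of the structure unchanged, gives a 73-fold higher number from compound 3 to compound 4 (1.86 log units; beyond the scatter). Among the compounds shown here, compound 1 and compound 2 also differ from compound 3 elsewhere, so only this pair isolates the carboxy group on the saturated ring carbon next to the ring nitrogen. It ties the low number of compound 3 to that single change, but nothing measured here accounts for the size of the step.

The compounds shown leave open whether a different group on this ring carbon, such as a primary amide or a hydroxymethyl group, would stay near compound 3 at 13.3 mL/min/kg or move towards compound 4. They also leave open whether the carboxylic acid gives the same result with the opposite configuration at this carbon.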